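From piperidin-1-yl to cycloheptylamino on a carbonyl carbon

This account rests on a few compounds, and the source may have more. Where it says the series, first, only, none or still open, it means among the compounds named here.

In a functional assay on BXPC-3 cells (Homo sapiens) for cytotoxicity, read by fluorescence, with a stated time of 48 h (a lower number here means that less compound is needed, a higher number that more compound is needed for the effect), compound 3 `CC(C)=CCC/C(C)=C/CC/C(C)=C/CSC[C@H](NC(=O)CCCCCN1CCCC1)C(=O)N1CCCCC1` gives 8700 nM, which lies within the scatter of both other measured compounds. Compound 1 `CC(C)=CCC/C(C)=C/CC/C(C)=C/CSC[C@H](NC(=O)CCCCCN1CCN(C)CC1)C(=O)NC1CCCCCC1` gives 6200 nM, and compound 2 `CC(C)=CCC/C(C)=C/CC/C(C)=C/CSC[C@H](NC(=O)CCCCCN1CCCC1)C(=O)NC1CCCCC1` gives 12700 nM. Within the data shown here, compound 4 `CC(C)=CCC/C(C)=C/CC/C(C)=C/CSC[C@H](NC(=O)CCCCCN1CCCC1)C(=O)NC1CCCCCC1` has no measurement yet. It differs from compound 3 by cycloheptylamino in place of piperidin-1-yl on a carbonyl carbon, with cycloheptylamino in place of piperidin-1-yl on a carbonyl carbon. The nearest measured step, with piperidin-1-yl in place of cyclohexylamino at such a carbon, was a 1.5-fold lower number from compound 2 to compound 3 (0.16 log units; within the scatter). Compound 1 already carries cycloheptylamino, though it differs elsewhere, and gives 6200 nM. No change beyond the scatter is therefore expected in this assay, and the expected step is a 1.1-fold lower number from compound 3 to compound 4 (0.04 log units; within the scatter). Compound 4 is estimated at 8000 nM, with an expected range of 4000 nM to 15000 nM.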

Compound 4, half-maximal effective concentration: 5800 nM
The estimate for compound 4 lay 1.4-fold (0.14 log units) above the measured number; the range from low to high includes it.
By their numbers in this assay, from the lowest: compounds 4, 1, 3 and 2 (each within the scatter of the next, the first and the last beyond it).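

In this assay, enlarging the ring on the amide-type nitrogen from cyclohexyl to cycloheptyl gives a modest step beyond the scatter (a 2.2-fold lower number from compound 2 to compound 4 (0.34 log units; beyond the scatter)). Cycloheptylamino in place of piperidin-1-yl on the carbonyl carbon stays within it (a 1.5-fold lower number from compound 3 to compound 4 (0.18 log units; within the scatter)), as does pyrrolidin-1-yl in place of 4-methylpiperazin-1-yl on the saturated chain carbon (a 1.1-fold lower number from compound 1 to compound 4 (0.03 log units; within the scatter)). No measurement shown explains these steps.

On these data alone, whether cyclooctyl on that nitrogen would extend the step remains open. So does the effect of morpholin-4-yl on that chain carbon.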